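This account rests on a few compounds, and the source may have more. Where it says the series, first, only, none or still open, it means among the compounds named here.

Measured compounds:
- compound 1 `Nc1cc(N)c2nc(-c3ccccc3)c(Oc3ccc(Cl)c(Cl)c3)nc2c1`; this assay: < 100000 nM
- compound 2 `CCOC(=O)[C@H](CCC(=O)O)NC(=O)c1ccc(Sc2nc3cc(N)cc(N)c3nc2-c2ccccc2)cc1`; this assay: < 100000 nM

In a functional assay on SN12C cells (Homo sapiens) for inhibition, read by sulforhodamine B assay, with a stated time of 48 h (on this read-out higher numbers stand for weaker inhibition of growth and lower numbers for stronger inhibition of growth), compound 1 gives < 100000 nM, which is a limit of the assay and not a number. For compound 2 the result < 100000 nM is likewise a limit. Compound 1 therefore cannot be placed against compound 2 on these numbers; both sit at the same limit (the limit of < 100000 nM in this assay, at which 2 of the 2 values shown sit), and no gap between them can be read off. Among the compounds with values here, no step between two measured compounds is available.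

Compound 3 `Nc1cc(N)c2nc(-c3ccccc3)c(NCc3ccc(F)cc3)nc2c1` has not been measured. It differs from compound 1 by (4-fluorobenzyl)amino in place of 3,4-dichlorophenoxy on an aromatic carbon. With both measured values at a limit, the direction and size of the step cannot be anchored on a known number. The expectation is for a step that the limit leaves unreadable from compound 1 to compound 3 that stays within the scatter of the assay, meaning no change beyond scatter in either direction. For compound 3 the expected value is 20000 nM, with a range from 3000 nM to 90000 nM.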

Compound 3, concentration for total growth inhibition: 23400 nM
Compound 3: the middle estimate sits 1.2-fold (0.07 log units) below what was measured; low and high end bracket the measured number.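

No step from compound 1 to compound 3 can be read in this assay, because compound 1 is known only as a limit: the limit of < 100000 nM in this assay, at which 2 of the 3 values shown sit.

Going by these compounds, whether (4-fluorobenzyl)amino in place of 3,4-dichlorophenoxy on an aromatic carbon changes growth inhibition, in which direction and by how much, remains open.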